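Acetyl to Carboxy at the Edge of Measurement

A few compounds are considered here, and "the series" means these few. Any claim that something is new, unique, unknown or untested is made for them only; others in the source may bear on it.

In a physicochemical assay for solubility, read by nephelometry, measured as kinetic solubility, at pH 2 (a lower number here means a less soluble compound, a higher number a more soluble compound), compound 1 (`CC(=O)c1ccc(NC(=O)Nc2ccc(F)c(C(F)(F)F)c2)cc1`) reads < 1.6 ug/mL and that is a limit of the assay, not a number. For the measured compounds named here, compound 2 (`N#Cc1ccc(NC(=O)Nc2ccnc(C(F)(F)F)c2)cc1`), the only other compound measured, gives 1.6 ug/mL in this assay as well. Compound 3 (`O=C(Nc1ccc(C(=O)O)cc1)Nc1ccc(F)c(C(F)(F)F)c1`) has hydroxy in place of methyl on a carbonyl carbon, acetyl to carboxy (hydroxy in place of methyl on a carbonyl carbon). Going by the values given here, no measured pair shows this change. A small rise, or none beyond the scatter, is expected, and the estimated step (an at least 1.2-fold higher number from compound 1 to compound 3 (0.09 log units; that floor lies within the scatter)) remains uncertain. For compound 3 the estimated solubility is 2 ug/mL in this assay, expected to fall between 1 ug/mL and 6 ug/mL on repeat measurement.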

Compound 3, solubility: < 1.6 ug/mL
Compound 3 ended at the assay's limit (the forecaster's own chance of this, stated with the estimate: 45%); middle value at least 1.2-fold (0.09 log units) from the limit.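

For the compounds shown here, compound 1 and compound 3 both stop at a limit of the assay rather than at a number, so no step between them can be read in this assay: the limit of < 1.6 ug/mL in this assay, at which 2 of the 3 values shown sit. On these data alone, whether acetyl or carboxy gives the more soluble compound stays open.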